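A Boc-to-ethylpyrimidine swap on a tetrahydropyridine nitrogen

The compounds below may be only part of what the source reports. "The series", "measured", "known", "first", "only" and "open" are said of these compounds alone.

Compound 1 `CC(C)(C)OC(=O)N1CC=C(c2nc(COc3ccc(OC(F)(F)F)cc3)cs2)CC1` carries a trifluoromethoxy group on its phenyl ether, but in a functional assay on isolated protein for agonist activity at Glucose-dependent insulinotropic receptor (Homo sapiens), read by HTRF and cAMP accumulation (a lower number here means that less compound is needed, a higher number that more compound is needed for the effect), compound 1 gives "not determined" (no result reported), so no result was obtained for it. Among the measured compounds shown here, compound 2 `CC(C)(C)OC(=O)N1CC=C(c2nc(COc3ccc(S(C)(=O)=O)cc3)cs2)CC1` replaces that group with a methylsulfonyl and is the only compound with a number: in this assay compound 2 gives 678 nM, which is therefore the sole reference point, with nothing to rank it against. Compound 3 `CCc1cnc(N2CC=C(c3nc(COc4ccc(S(C)(=O)=O)cc4)cs3)CC2)nc1` keeps the whole shared core and changes only the cap on the ring nitrogen: 5-ethylpyrimidin-2-yl in place of tert-butoxycarbonyl on an amine nitrogen in a ring. For the measured compounds named here, no measured pair shows what such a cap change does, so any expectation rests on the single value of compound 2 alone. With that caveat, a modest gain is expected, the step of a 2.3-fold lower number from compound 2 to compound 3 (0.35 log units; beyond the scatter) being estimated to exceed the usual scatter but not by much. Compound 3 is expected to give 300 nM, within a range of 60 nM to 1500 nM.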

Compound 3, half-maximal effective concentration: 70.5 nM
Estimate against measurement, compound 3: 4.3-fold (0.63 log units) above, within the range that was stated.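

On the ring nitrogen of the shared core, the cap strongly affects the result in this assay: 5-ethylpyrimidin-2-yl in place of tert-butoxycarbonyl gives a 9.6-fold lower number from compound 2 to compound 3 (0.98 log units; beyond the scatter) and so a step well beyond the scatter. Among the compounds shown here, compound 2 alone could not show this, since it offered only one value at this position. No measurement shown gives a reason for the step.

Going by these compounds, it remains open whether the gain comes from the pyrimidine ring or from its ethyl group, which an unsubstituted pyrimidin-2-yl, a pyridin-2-yl or a longer chain such as propyl on the pyrimidine could help to separate. On these data alone, it is also open whether the same cap gives a similar step with a different group on the phenyl ether, such as the trifluoromethoxy of compound 1, which has no reported result.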